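A few compounds are considered here, and "the series" means these few. Any claim that something is new, unique, unknown or untested is made for them only; others in the source may bear on it.

Compound 2 `O=C(CSc1nnc(COc2ccc3ccccc3c2)n1Cc1ccccc1)Nc1ccc(Br)cc1` stands at the higher of the two numbers in a toxicity assay on MT4 cells (Homo sapiens) for cytotoxicity, read by MTT assay, with a stated time of 5 days; a higher number here means that more compound is tolerated, a lower number that less compound is tolerated: compound 2 reads 58.1 ug/mL, while compound 1 `CCOC(=O)c1ccc(NC(=O)CSc2nnc(COc3cc(C)ccc3C(C)C)n2Cc2ccccc2)cc1` reads 19.8 ug/mL, a gap beyond the scatter. Compound 3 `CCOC(=O)c1ccc(NC(=O)CSc2nnc(COc3ccc4ccccc4c3)n2Cc2ccccc2)cc1` is not yet measured. Relative to compound 2 the change is ethoxycarbonyl in place of bromo on an aromatic carbon; the rest of the molecule is kept. Going by the values given here, compound 1 already carries the ethoxycarbonyl group on the amide aryl ring but differs from compound 3 in the ether portion as well, so no measured pair isolates this single change. A moderate downward step in this assay is expected, since compound 1 with the same ethoxycarbonyl group gave 19.8 ug/mL. The expected step is a 1.9-fold lower number from compound 2 to compound 3 (0.29 log units; within the scatter). Compound 3 is expected to give about 30 ug/mL, with a range from 12 ug/mL to 70 ug/mL, the width reflecting that the ether portion also differs from compound 1.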

Compound 3, half-maximal cytotoxic concentration: >= 90.7 ug/mL
Compound 3 was reported as a limit (the forecaster's own chance of this, stated with the estimate: 5%); middle value at least 3.0-fold (0.48 log units) from the limit.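

In this assay compound 3 gives >= 90.7 ug/mL, which is a limit of the assay and not a number. With the 4-(ethoxycarbonyl)phenyl kept, naphthalen-2-yl in place of 2-isopropyl-5-methylphenyl on the ether oxygen gives an at least 4.5-fold higher number from compound 1 to compound 3 (0.66 log units; beyond the scatter), so the low number of compound 1 cannot be tied to the ethoxycarbonyl group alone. With the naphthalen-2-yl kept, ethoxycarbonyl in place of bromo on the aromatic carbon gives an at least 1.5-fold higher number from compound 2 to compound 3 (0.19 log units; that floor lies within the scatter), so this change shows no lowering of the number, although its floor does not separate the two compounds.

Going by these compounds, the true size of this step remains unknown while compound 3 stands at a limit. Also open, on these data alone, is whether a carboxylic acid or an amine in place of the ethoxycarbonyl would give a number that can be read in this assay.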